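Replacing bromo with trifluoromethyl on a shared core

The source may report more compounds than this note shows. Statements on the series, on what has been measured and on what is new or still open speak of the compounds shown alone.

- compound 1 `CN1C/C(=C\c2ccc(C(F)(F)F)cc2)C(=O)/C(=C/c2ccccc2F)C1` gives 5930 nM
- compound 2 `CN1C/C(=C\c2ccc(Cl)cc2)C(=O)/C(=C/c2cccc([N+](=O)[O-])c2)C1` gives 7870 nM
- compound 3 `CN1C/C(=C\c2ccc(Br)cc2)C(=O)/C(=C/c2cccc([N+](=O)[O-])c2)C1` gives 7690 nM
- compound 4 `CN1C/C(=C\c2ccc(C(F)(F)F)cc2)C(=O)/C(=C/c2cccc([N+](=O)[O-])c2)C1` is not yet measured

In a functional assay on THP-1 cells (Homo sapiens) for cytotoxicity, read by MTT assay, with a stated time of 24 h (on this read-out higher numbers stand for weaker inhibition and lower numbers for stronger inhibition), compound 3 gives 7690 nM, within the scatter of both compound 1 and compound 2. Compound 4 has trifluoromethyl in place of bromo on an aromatic carbon, para to a large group: trifluoromethyl in place of bromo on an aromatic carbon. Among the compounds with values here, the one measured step that bears on this change is a 1.0-fold lower number from compound 2 to compound 3 (0.01 log units; within the scatter), which lies within the scatter. Compound 1 also carries trifluoromethyl and gives 5930 nM, but it differs from compound 4 in another place as well. No shift beyond the scatter is therefore expected in this assay, and the estimated change is a 1.1-fold lower number from compound 3 to compound 4 (0.04 log units; within the scatter). For compound 4 the estimate is 7000 nM, with an expected range from 4000 nM to 12000 nM.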

Compound 4, half-maximal inhibitory concentration: 970 nM
Compound 4: middle estimate off by 7.2-fold (0.86 log units), on the high side, and the stated range ends above it.
By their numbers in this assay, from the lowest: compound 4; then compounds 1, 3 and 2 (each within the scatter of the next).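

In this assay the group on this aromatic carbon proves to matter. Trifluoromethyl in place of bromo gives a 7.9-fold lower number from compound 3 to compound 4 (0.90 log units; beyond the scatter) and trifluoromethyl in place of chloro gives an 8.1-fold lower number from compound 2 to compound 4 (0.91 log units; beyond the scatter) even though swapping chloro for bromo gave only a 1.0-fold lower number from compound 2 to compound 3 (0.01 log units; within the scatter) and so had hinted at no such sensitivity. Trifluoromethyl does not act alone, since 3-nitrophenyl in place of 2-fluorophenyl gives a 6.1-fold lower number from compound 1 to compound 4 (0.79 log units; beyond the scatter) with trifluoromethyl present in both compounds.

No measurement at hand gives a reason for these steps. Still open, going by these compounds, is whether an amine or a methoxy group on this carbon would behave like trifluoromethyl or like the halogens.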